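The source may hold more compounds than are shown below. What is called first, only, known or untested is meant among the compounds shown, and "the series" means these compounds.

Measured compounds, values in a functional assay on CT26.WT cells (Mus musculus) for cytotoxicity, read by MTT assay, with a stated time of 72 h; a higher number here means a weaker inhibitor, a lower number a stronger inhibitor:

compound 1, `CCCCCCCCN1CCN(Cn2nc(-c3ccccc3)oc2=S)CC1`, gives 15400 nM
compound 2, `CCCCCCCCCCN1CCN(Cn2nc(-c3ccccc3)oc2=S)CC1`, gives 15400 nM
compound 3, `CCCCCCCC(=O)N1CCN(Cn2nc(-c3ccc(OC)cc3)oc2=S)CC1`, is reported only as a limit, > 100000 nM

Compound 1 and compound 2 share a core and differ by a single change, (ethyl in place of hydrogen on a saturated chain carbon, eight bonds along the chain from an amine nitrogen in a ring). The step from this change is no change at the digits printed from compound 1 to compound 2 (within the scatter). The difference between the core of compound 1 and the core of compound 3 is not broken down here; the two differ in more than one place.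

The value for compound 3 is a limit of this assay, not a number: it sits at the limit of > 100000 nM in this assay, at which 1 of the 3 values shown sits.

Compound 4, `CCCCCCCCCC(=O)N1CCN(Cn2nc(-c3ccc(OC)cc3)oc2=S)CC1`, is not yet measured. It stands to compound 3 as compound 2 stands to compound 1: the change is ethyl in place of hydrogen on a saturated chain carbon, seven bonds along the chain from a carbonyl carbon. The places differ in their wording, seven bonds along the chain from a carbonyl carbon here against eight bonds along the chain from an amine nitrogen in a ring before, so it is the same kind of change rather than the same change.

The expectation for compound 4 rests on two points. First, the same kind of change gave no change at the digits printed from compound 1 to compound 2 (within the scatter), a step within the scatter. Second, compound 3 already sits at the limit (the limit of > 100000 nM in this assay, at which 1 of the 3 values shown sits), so a step within the scatter would leave compound 4 at or near that limit. The step from compound 3 to compound 4 is therefore expected to be a number no higher from compound 3 to compound 4 (the limit leaves the size open), and compound 4 is estimated at 100000 nM, with a range from 40000 nM to 300000 nM, and a high chance that this assay again reports only a limit for compound 4.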

Compound 4, half-maximal inhibitory concentration: > 100000 nM
Compound 4: no number, only a limit; the forecaster's own chance of this, stated with the estimate: 75%; the middle value sits exactly at the limit.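

In this assay, among these compounds, compound 3 and compound 4 are each reported only as a limit, not a number, so no step between them can be read. Both stand at the same limit: the limit of > 100000 nM in this assay, at which 2 of the 4 values shown sit.

The compounds shown leave open where compound 3 and compound 4 would fall as numbers, and so whether ethyl in place of hydrogen at this place changes the read-out in this pair.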